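Adding a methyl to an amino group at the limit

A few compounds are considered here, and "the series" means these few. Any claim that something is new, unique, unknown or untested is made for them only; others in the source may bear on it.

In a functional assay on HCT-116 cells (Homo sapiens) for antiproliferative activity, read by MTT assay, with a stated time of 72 h (on this read-out lower numbers stand for stronger inhibition of growth and higher numbers for weaker inhibition of growth), compound 1 (`COc1cc(OC)c(/C=C/S(=O)(=O)Cc2nc(Cl)ncc2OC)c(OC)c1`) gives > 10000 nM, which is a limit of the assay and not a number. Compound 2 (`COc1cc(OC)c(/C=C/S(=O)(=O)Cc2nc(N)ncc2OC)c(OC)c1`) gives > 10000 nM, which is likewise only a limit. Compound 2 therefore has no measured potency to build on, and the evidence amounts to the limit of > 10000 nM in this assay, at which 2 of the 2 values shown sit.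

Compound 3 (`CNc1ncc(OC)c(CS(=O)(=O)/C=C/c2c(OC)cc(OC)cc2OC)n1`) differs from compound 2 in one place: methyl in place of hydrogen on a nitrogen on an aromatic ring. In words, amino becomes methylamino. For the measured compounds named here, the only measured step that bears on this change is a step that the two limits leave unreadable from compound 1 to compound 2. Going by the values given here, it sits on the same core but offers no size to carry forward, and no measured step covers a methyl group on this nitrogen.

Growth inhibition is not expected to appear with this change, because compound 2 stays at the limit > 10000 nM. In this assay the expected result is a step that the limit leaves unreadable from compound 2 to compound 3, with no shift beyond the scatter in either direction. Compound 3 is estimated at 12000 nM, with an expected range of 4000 nM to 30000 nM, and it may well be reported only as a limit.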

Compound 3, concentration for 50% growth inhibition: > 10000 nM
Compound 3: only a limit was reported (the forecaster's own chance of this, stated with the estimate: 80%); the middle value lies beyond the limit too.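

In this assay compound 3 gives > 10000 nM, which is a limit of the assay and not a number. No step can be read among compound 1, compound 2 and compound 3, so the evidence remains a shared limit: the limit of > 10000 nM in this assay, at which 3 of the 3 values shown sit. The compounds shown leave open whether any group on this nitrogen would bring measurable growth inhibition.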